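The source may hold more compounds than are shown below. What is called first, only, known or untested is meant among the compounds shown, and "the series" means these compounds.

Compound 2 `CCn1nc(-c2cccs2)c2sccc2c1=O` stands second highest of the three numbers in an assay on CHO cells for displacement of a labelled ligand from adenosine receptor A1 (Homo sapiens), read by scintillation counting, with a stated time of 90 min (on this read-out lower numbers stand for stronger inhibition and higher numbers for weaker inhibition), where compound 2 gives 724 nM. Compound 1 `CCn1nc(-c2ccccc2)c2sccc2c1=O` gives 2670 nM and compound 3 `CCn1nc(-c2nccs2)c2sccc2c1=O` gives 113 nM, so the step of a 3.7-fold lower number from compound 1 to compound 2 (0.57 log units; beyond the scatter) is modest, the step of a 6.4-fold lower number from compound 2 to compound 3 (0.81 log units; beyond the scatter) is modest, and the step of a 24-fold lower number from compound 1 to compound 3 (1.37 log units; beyond the scatter) is large. Compound 4 `Nn1nc(-c2cccs2)c2sccc2c1=O` differs from compound 2 in amino in place of ethyl on an aromatic nitrogen. Going by the values given here, none of the measured steps touches this position; all three swap the aryl group on an aromatic carbon, so they give no guide to size or direction here. Compound 4 is therefore expected to show a step of a 1.0-fold lower number from compound 2 to compound 4 (0.01 log units; within the scatter) that stays within the scatter. The estimate for compound 4 in this assay is 700 nM, with a range from 200 nM to 2500 nM.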

Compound 4, inhibition constant: 3540 nM
Estimate against measurement, compound 4: 5.1-fold (0.70 log units) below; the whole stated range lies below it.
By their numbers in this assay, from the lowest: compound 3; then compound 2; then compounds 1 and 4 (each within the scatter of the next).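

In this assay, the group on the aromatic nitrogen proves not to be indifferent: amino in place of ethyl gives a 4.9-fold higher number from compound 2 to compound 4 (0.69 log units; beyond the scatter), a move towards weaker inhibition. This is the first step shown at this position, and the aryl swaps gave no sign of it. No measurement shown accounts for the shift.

From the compounds shown here alone, whether it reflects the entering amino or the departing ethyl stays open; a methyl, a propyl chain or a dimethylamino group on that nitrogen would help separate the two. Also open, going by these compounds, is whether the same change on compound 3 would give a step of similar size and direction.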